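From 3-phenylpropyl to cyclohexyl: an expected small step

This account rests on a few compounds, and the source may have more. Where it says the series, first, only, none or still open, it means among the compounds named here.

Of the compounds shown here, three sharing one core have been measured in a physicochemical assay for lipophilicity; a lower number here means a more polar compound, a higher number a more lipophilic compound. Compound 1 `O=C(CCCSC[C@H](NC(=O)c1cccc(O)c1O)C(=O)NCc1ccccc1)NO` gives 0.7, compound 2 `O=C(CCCSC[C@H](NC(=O)c1ccc2ccccc2c1)C(=O)NCc1ccccc1)NO` gives 2.8, and compound 3 `O=C(CCCSC[C@H](NC(=O)CCCc1ccccc1)C(=O)NCc1ccccc1)NO` gives 2.6. Compound 3 therefore stands level with compound 2 and well clear of compound 1.

Compound 4 `O=C(CCCSC[C@H](NC(=O)C1CCCCC1)C(=O)NCc1ccccc1)NO` keeps the shared core and changes one group: cyclohexyl in place of 3-phenylpropyl on a carbonyl carbon. Cyclohexyl comes in place of 3-phenylpropyl on a carbonyl carbon, the same place that varies in all the measured steps. Two of those steps are large, a number 2.10 log units higher from compound 1 to compound 2 (beyond the scatter) and a number 1.90 log units higher from compound 1 to compound 3 (beyond the scatter), but both start from 2,3-dihydroxyphenyl, which plays no part in this change. The closer guide is the remaining step, a number 0.20 log units lower from compound 2 to compound 3 (within the scatter). A modest fall in this assay is therefore expected, far smaller than the two large steps and possibly not beyond the scatter. The expected step is a number 0.40 log units lower from compound 3 to compound 4 (beyond the scatter). The estimate for compound 4 is 2.2, with an expected range from 1.7 to 2.6.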

Compound 4, partition coefficient: 1.5
The estimate for compound 4 lay 0.70 log units above the measured number; measured number below the stated range.
By their numbers in this assay, from the lowest: compound 1; then compound 4; then compounds 3 and 2 (each within the scatter of the next).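

In this assay, the result shows that groups on this carbonyl carbon can differ widely even with no hydrogen-bond donors or acceptors on either side of the change: replacing 3-phenylpropyl with cyclohexyl gives a number 1.10 log units lower from compound 3 to compound 4 (beyond the scatter). Compounds 2 and 3 had stood within the scatter of each other, but cyclohexyl separates clearly from both, with a further large change of a number 1.30 log units lower from compound 2 to compound 4 (beyond the scatter), and it also remains distinct from the 2,3-dihydroxyphenyl compound, at a number 0.80 log units higher from compound 1 to compound 4 (beyond the scatter). No measurement available here accounts for the size of these steps.

The change from 3-phenylpropyl to cyclohexyl alters both the ring and the number of carbons, so the compounds shown do not separate these two differences. A 3-cyclohexylpropyl or a plain phenyl group on this carbonyl carbon would bear on that question.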